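A few compounds are considered here, and "the series" means these few. Any claim that something is new, unique, unknown or untested is made for them only; others in the source may bear on it.

Measured so far in an ADME assay on Vero cells (Chlorocebus sabaeus) for cytotoxicity, read by MTT assay, with a stated time of 48 h; on this read-out higher numbers stand for lower toxicity in this test and lower numbers for higher toxicity in this test:
compound 1 `C=C1CC[C@@H]2[C@](C)(CO)[C@H](O)CC[C@@]2(C)[C@@H]1C/C=C1/C(=O)OC[C@H]1Oc1ccnc2ccccc12` gives 22800 nM
compound 2 `C=C1CC[C@@H]2[C@](C)(CO)[C@H](O)CC[C@@]2(C)[C@@H]1C/C=C1/C(=O)OC[C@@H]1Oc1ccnc2ccccc12` gives 20700 nM

Going by the values given here, the only measured step, a 1.1-fold lower number from compound 1 to compound 2 (0.04 log units; within the scatter), is within the scatter; it rests on (the fact that compounds 1 and 2 differ only in the configuration as drawn), so compound 2 and compound 1 sit together on this read-out. Compound 3 `C=C1CC[C@@H]2[C@](C)(CO)[C@H](O)CC[C@@]2(C)[C@@H]1C/C=C1/C(=O)OC[C@@H]1Oc1cccc2cccnc12` differs from compound 2 by quinolin-8-yl in place of quinolin-4-yl on an oxygen on a saturated carbon. Among the compounds with values here, no measured step changes the ring attachment, so the one step available gives no direction for this change. With the same atoms kept, the step expected from compound 2 to compound 3 is a 1.0-fold higher number from compound 2 to compound 3 (0.01 log units; within the scatter), none beyond the scatter. Compound 3 is therefore estimated at 21000 nM, within 8000 nM to 55000 nM.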

Compound 3, half-maximal cytotoxic concentration: 20800 nM
For compound 3 the middle estimate is 1.0-fold (0.00 log units) above the measured one; low and high end bracket the measured number.
By their numbers in this assay, from the lowest: compounds 2, 3 and 1 (each within the scatter of the next).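

In this assay, quinolin-8-yl in place of quinolin-4-yl on the oxygen gives a 1.0-fold higher number from compound 2 to compound 3 (0.00 log units; within the scatter). The earlier compounds shown here tested only configuration at the saturated ring carbon, whereas this pair shows that the read-out does not separate these two attachments of the same group. Nothing on hand accounts for this result.

Open, going by these compounds, is whether any other group on this oxygen would shift the number, such as an amine, a carboxylic acid or a longer chain. Also open, on these data alone, is how quinolin-8-yl behaves with the configuration of compound 1.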